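The source may hold more compounds than are shown below. What is called first, only, known or untested is meant among the compounds shown, and "the series" means these compounds.

Measured compounds and their results:
Compound 1 `O=C(/C=C/c1ccc(F)cc1)c1ccc(OCc2ccccc2)cc1` returns in a functional assay on CAL-51 cells (Homo sapiens) for inhibition, read by sulforhodamine B assay, with a stated time of 3 days (a higher number here means a weaker inhibitor of growth, a lower number a stronger inhibitor of growth), only the limit > 50000 nM.
Compound 2 `COc1ccc(/C=C/C(=O)c2ccc(OCc3ccccc3)cc2)cc1` returns in this assay only the limit > 50000 nM.
Compound 3 `O=C(/C=C/c1ccc(Cl)cc1)c1ccc(OCc2ccccc2)cc1` returns in this assay only the limit > 50000 nM.

Compound 3 therefore does not stand at a number at all: it sits, together with the other two compounds, at the limit of > 50000 nM in this assay, at which 3 of the 3 values shown sit. The three steps that connect the measured compounds, a step that the two limits leave unreadable from compound 1 to compound 2, a step that the two limits leave unreadable from compound 1 to compound 3 and a step that the two limits leave unreadable from compound 2 to compound 3, are all at the same position of the shared core and none of them can be read, since both ends of each are limits.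

Compound 4 `O=C(/C=C/c1ccccc1)c1ccc(OCc2ccccc2)cc1` differs from compound 3 in exactly that position: hydrogen in place of chloro on an aromatic carbon. The measured steps that bear on this change give no readable size and no direction, so nothing in this assay points to a step beyond the scatter. Compound 4 is accordingly expected to remain at the limit, with a step that the limit leaves unreadable from compound 3 to compound 4 estimated from compound 3. The estimate for compound 4 in this assay is 80000 nM, ranging from 30000 nM to 250000 nM.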

Compound 4, concentration for 50% growth inhibition: 28900 nM
For compound 4 the middle estimate is 2.8-fold (0.44 log units) above the measured one; the measured number lies below the stated range.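

In this assay, among these compounds, compound 4, which carries hydrogen at this position, gives the first number rather than a limit, and the fluoro, methoxy and chloro compounds remain at the limit: the limit of > 50000 nM in this assay, at which 3 of the 4 values shown sit. Measured against those limits, the change to hydrogen reads as an at least 1.7-fold lower number from compound 3 to compound 4 (0.23 log units; that floor lies within the scatter), as an at least 1.7-fold lower number from compound 2 to compound 4 (0.23 log units; that floor lies within the scatter) and as an at least 1.7-fold lower number from compound 1 to compound 4 (0.23 log units; that floor lies within the scatter). Each of these is only a floor, so a true step beyond the scatter is neither shown nor ruled out, and the steps among the three substituted compounds still cannot be read.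

Going by these compounds, how the fluoro, methoxy and chloro compounds rank against one another therefore stays open. Also open, on these data alone, is whether an amine or a carboxylic acid on this aromatic carbon would give a lower number than compound 4 does.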